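A few compounds are considered here, and "the series" means these few. Any claim that something is new, unique, unknown or untested is made for them only; others in the source may bear on it.

Working notes on the series. In a functional assay on HeLa cells (Homo sapiens) for inhibition, read by MTT assay, with a stated time of 72 h (a lower number here means a stronger inhibitor, a higher number a weaker inhibitor), compound 1 `O=[N+]([O-])c1ccc(-c2nnc(SCCCN3CCN(c4nc5ccccc5o4)CC3)o2)cc1` gives 114000 nM and compound 2 `c1ccc(-c2nnc(SCCCN3CCN(c4nc5ccccc5o4)CC3)o2)cc1` gives 67000 nM, so the two cannot be told apart. Going by the values given here, the only measured step, a 1.7-fold lower number from compound 1 to compound 2 (0.23 log units; within the scatter), puts hydrogen in place of nitro on an aromatic carbon.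

Compound 3 `O=C(NCc1nnc(SCCCN2CCN(c3nc4ccccc4o3)CC2)o1)c1ccccc1` has not yet been measured. It carries benzamidomethyl in place of phenyl on an aromatic carbon of the five-membered aromatic ring with 2 nitrogen and 1 oxygen: benzamidomethyl in place of phenyl on an aromatic carbon. Among the compounds with values here, no measured step removes the phenyl, so the data give only weak guidance on this change. Within the data shown here, the sole precedent, a 1.7-fold lower number from compound 1 to compound 2 (0.23 log units; within the scatter), stays within the scatter, and no shift beyond the scatter is expected in this assay, in either direction. The estimated step is a 1.1-fold lower number from compound 2 to compound 3 (0.05 log units; within the scatter). For compound 3 the expected value is 60000 nM, with an estimated range of 20000 nM to 150000 nM.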

Compound 3, half-maximal inhibitory concentration: 63900 nM
Compound 3: the middle estimate sits 1.1-fold (0.03 log units) below what was measured; the measured number falls inside the stated range.
By their numbers in this assay, from the lowest: compounds 3, 2 and 1 (each within the scatter of the next).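

The aromatic carbon of the five-membered aromatic ring with 2 nitrogen and 1 oxygen now carries a change that replaces the whole phenyl, not only a substituent on it. In this assay, benzamidomethyl in place of phenyl gives a 1.0-fold lower number from compound 2 to compound 3 (0.02 log units; within the scatter), and benzamidomethyl in place of 4-nitrophenyl gives a 1.8-fold lower number from compound 1 to compound 3 (0.25 log units; within the scatter), so an aromatic ring attached directly at this position is not needed for a number within the scatter of the other two compounds. No available evidence bears on the reason for this result.

On these data alone, it remains open whether any group at this position can move the number beyond the scatter. An amine or a carboxylic acid on the benzene ring of benzamidomethyl, or a longer chain in place of benzamidomethyl, would test that.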